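A Thiophene in Place of Bromophenyl on a Urea

The source may hold more compounds than are shown below. What is called first, only, known or untested is meant among the compounds shown, and "the series" means these compounds.

Compound 1 `O=C(Nc1ccc(Br)cc1)Nc1ccc(Nc2ncnc3c2OCCN3)cc1`: > 10000 nM in an assay on isolated protein for inhibition of proto-oncogene tyrosine-protein kinase receptor Ret variant V804L (Homo sapiens), read by 33P incorporation, with stated times of 15 min and 40 min; a higher number here means a weaker inhibitor, a lower number a stronger inhibitor
Compound 2 `O=C(Nc1ccc(Nc2ncnc3c2OCCN3)cc1)Nc1ccc(C(F)(F)F)cc1`: 2470 nM in this assay
Compound 3 `O=C(Nc1ccc(Nc2ncnc3c2OCCN3)cc1)Nc1cccc2ccccc12`: > 10000 nM in this assay

Three ureas built on the shared core have been measured. Compound 1 gives only a limit in this assay, not a number. Compound 3 likewise stops at a limit. Going by the values given here, compound 2 alone yields a number, and the step of an at least 4.0-fold lower number from compound 1 to compound 2 (0.60 log units; beyond the scatter) is the one comparison that can be read in full; the step of an at least 4.0-fold higher number from compound 2 to compound 3 (0.60 log units; beyond the scatter) runs the other way, while a step that the two limits leave unreadable from compound 1 to compound 3 cannot be read because both ends sit at the limit of > 10000 nM in this assay, at which 2 of the 3 values shown sit.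

Compound 4 `O=C(Nc1ccc(Nc2ncnc3c2OCCN3)cc1)Nc1cccs1` differs from compound 1 by thiophen-2-yl in place of 4-bromophenyl on an amide-type nitrogen. Among the compounds with values here, none of the measured steps swaps the whole aryl group for a five-membered ring, so none bears directly on this change; the readable steps concern trifluoromethyl against bromo and naphthalen-1-yl against 4-(trifluoromethyl)phenyl. With compound 1 at a limit, a weakening step from it cannot be seen at all. Compound 4 is therefore expected to remain weak, with a number no higher from compound 1 to compound 4 (the limit leaves the size open) expected to be small. Compound 4 is estimated at 10000 nM, within a range from 2500 nM to 40000 nM, and a limit is again quite likely.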

Compound 4, half-maximal inhibitory concentration: > 10000 nM
Compound 4: only a limit was reported; the forecaster's own chance of this, stated with the estimate: 60%; the middle value lies on the limit itself.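

In this assay compound 4 gives > 10000 nM, which is a limit and not a number. Thiophen-2-yl on the amide-type nitrogen thus joins 4-bromophenyl and naphthalen-1-yl at that limit, and 4-(trifluoromethyl)phenyl remains the only group of the four to give a number, as an at least 4.0-fold higher number from compound 2 to compound 4 (0.60 log units; beyond the scatter) shows. The steps among compound 1, compound 3 and compound 4 cannot be read, and these three cannot be ranked, as all of them rest on one limit: the limit of > 10000 nM in this assay, at which 3 of the 4 values shown sit.

As far as these compounds go, how far each of the three lies past that limit stays open. Also open, from the compounds shown here alone, is whether a thiophen-2-yl carrying trifluoromethyl, or a phenyl ring carrying a nitrile, a methoxy group or an amine, would give a number lower than that of compound 2.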